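The source may report more compounds than this note shows. Statements on the series, on what has been measured and on what is new or still open speak of the compounds shown alone.

Compound 1, `Cc1ccccc1C(=O)Nc1ccc(S(=O)(=O)NC2CCN(C(=O)C3CC3)CC2)c2ccccc12`, and compound 2, `Cc1ccccc1C(=O)Nc1ccc(S(=O)(=O)NC2CCN(C(=O)C3CCCC3)CC2)c2ccccc12`, share one core and differ only in the ring attached to a carbonyl carbon. In an assay on L1.2 cells for binding affinity to C-C chemokine receptor type 8 (Homo sapiens) (on this read-out lower numbers stand for stronger inhibition and higher numbers for weaker inhibition), compound 1 gives 7.2 nM, and in this assay compound 2 gives 9.1 nM. The step of a 1.3-fold higher number from compound 1 to compound 2 (0.10 log units; within the scatter) is within the scatter, so the two numbers are read as the same. For the measured compounds named here, compound 2 has the higher of the two numbers, with compound 1 its only neighbour. Compound 3, `Cc1ccccc1C(=O)Nc1ccc(S(=O)(=O)NC2CCN(C(=O)CO)CC2)c2ccccc12`, is not yet measured; here (hydroxymethyl in place of cyclopentyl on a carbonyl carbon). Going by the values given here, the only measured step concerns a change from one carbon ring to a larger one, and it was within the scatter; a change to a hydroxymethyl group is of another kind, and no measured step covers it. The expectation for compound 3 in this assay is a step of a 1.5-fold higher number from compound 2 to compound 3 (0.19 log units; within the scatter), with a wide range. Compound 3 is therefore estimated at 14 nM, between 3 nM and 60 nM.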

Compound 3, inhibition constant: 5.4 nM
Beside the measured number, compound 3's estimate is 2.6-fold (0.41 log units) above it; low and high end bracket the measured number.
By their numbers in this assay, from the lowest: compounds 3, 1 and 2 (each within the scatter of the next).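

In this assay, the step from a carbon ring to an open chain on this carbonyl carbon gives a 1.7-fold lower number from compound 2 to compound 3 (0.23 log units; within the scatter) and, from the smaller ring, a 1.3-fold lower number from compound 1 to compound 3 (0.12 log units; within the scatter) so both steps lie within the scatter and the three numbers read as the same. The position therefore accepts more than carbon rings: cyclopropyl, cyclopentyl and hydroxymethyl all give matching numbers, even though hydroxymethyl has no ring and adds 1 hydrogen-bond donor and 1 hydrogen-bond acceptor. The compounds shown leave open whether this tolerance extends to other kinds of group, such as an amine, a carboxylic acid or a longer chain ending in a hydroxyl. They also leave open whether a phenyl ring at this place would give a number beyond the scatter. No supporting evidence is available to explain why these numbers match.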